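Sulfonyl-aryl swap in a quinoline sulfone series

A few compounds are considered here, and "the series" means these few. Any claim that something is new, unique, unknown or untested is made for them only; others in the source may bear on it.

Measured so far:
compound 1 `O=S(=O)(c1ccc(F)c(Cl)c1)c1cnc2c(F)cccc2c1-c1cccc(Cl)c1` — 0.18 mL/min
compound 2 `O=S(=O)(c1ccc(F)c(Cl)c1)c1cnc2c(F)cccc2c1-c1ccccc1F` — 1.39 mL/min
compound 3 `COc1ccc(-c2c(S(=O)(=O)c3cccc(F)c3)cnc3cc(F)ccc23)cc1` — 1.89 mL/min

In an ADME assay on microsomes from liver (Homo sapiens) for metabolic stability, tested at 2.5 uM (a higher number here means faster removal of the compound, a lower number slower removal), compound 1 gives the lowest of the three numbers; compound 2 sits higher, as the step of a 7.7-fold higher number from compound 1 to compound 2 (0.89 log units; beyond the scatter) shows, and compound 3, which differs from both in several places, lies higher still at 1.89 mL/min.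

Compound 4 `O=S(=O)(c1cc(Cl)cc(Cl)c1)c1cnc2c(F)cccc2c1-c1cccc(Cl)c1` is not yet measured. It differs from compound 1 as follows: 3,5-dichlorophenyl in place of 3-chloro-4-fluorophenyl on a sulfonyl sulfur.

Within the data shown here, the one measured step, a 7.7-fold higher number from compound 1 to compound 2 (0.89 log units; beyond the scatter), changes the aryl group on the aromatic carbon of the shared core, not the aryl group on the sulfonyl sulfur, so no measured step bears directly on the change from compound 1 to compound 4. Compound 3 carries a different sulfonyl aryl, but also other changes, so its value alone cannot isolate the effect at this position. Among the measured compounds shown here, with no direct precedent, the expectation for compound 4 is a step of a 1.9-fold higher number from compound 1 to compound 4 (0.29 log units; within the scatter), which is within the scatter or at most modest. Compound 4 is therefore estimated at 0.35 mL/min, with a range of 0.12 mL/min to 1.1 mL/min.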

Compound 4, intrinsic clearance in a liver preparation (reported as CLH), per the amount of preparation that the assay uses: 1.2 mL/min
For compound 4 the middle estimate is 3.4-fold (0.54 log units) below the measured one; the whole stated range lies below it.
By their numbers in this assay, from the lowest: compound 1; then compounds 4, 2 and 3 (each within the scatter of the next).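

In this assay, the aryl group on the sulfonyl sulfur proves to be a position that matters, not a silent one: a 6.7-fold higher number from compound 1 to compound 4 (0.82 log units; beyond the scatter) comes from an exchange of one aryl group for another with the same heavy-atom count. Together with a 7.7-fold higher number from compound 1 to compound 2 (0.89 log units; beyond the scatter), this shows that the low number of compound 1 does not survive a single change at either of the two aryl places shown. Nothing at hand explains why this exchange moves the number.

Because the fluorine and chlorine pattern changes in one step, the compounds shown cannot say which part of the exchange matters. Also open, as far as these compounds go, is how the number responds on the sulfonyl sulfur to an unsubstituted phenyl, or to a phenyl carrying a nitrile or an amine.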